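The source may report more compounds than this note shows. Statements on the series, on what has been measured and on what is new or still open speak of the compounds shown alone.

Measured compounds:
compound 1 `Cc1nn(-c2ncnc3nc[nH]c23)c2c1C(OCCn1nccc1C)CC(=O)N2` with 10 nM in a functional assay on HEK293 cells for agonist activity at G-protein coupled receptor 39 (Homo sapiens), read by scintillation proximity assay and inositol phosphate accumulation, with a stated time of 75 min, in the presence of a further agent that is not named here; on this read-out higher numbers stand for an effect only at larger amounts of compound and lower numbers for an effect already at smaller amounts
compound 2 `Cc1nn(-c2ncnc3nc[nH]c23)c2c1C(OCc1ccc(F)cc1)CC(=O)N2` with 1 nM

Compound 2 gives the lowest of the two numbers shown; the only comparison is compound 1, and the step of a 10-fold lower number from compound 1 to compound 2 (1.00 log units; beyond the scatter) places compound 2 beyond the scatter from it. Compound 3 `Cc1nn(-c2ncnc3nc[nH]c23)c2c1C(OC(=O)c1ccc(F)cc1)CC(=O)N2` is the same as compound 2 except for the change ((4-fluorophenyl)carbonyl in place of 4-fluorobenzyl on an oxygen on a saturated carbon). Within the data shown here, no measured pair shows this particular change. Among the measured compounds shown here, the one step that exists, a 10-fold lower number from compound 1 to compound 2 (1.00 log units; beyond the scatter), concerns the group sitting on the saturated chain carbon bound to the oxygen, not the oxygen-bound group itself, so it speaks only to the general sensitivity of that position: a change there was enough to move the number beyond the scatter. The expectation for compound 3 therefore rests on that sensitivity alone and on the retention of the 4-fluorophenyl ring. Compound 3 is estimated at 3 nM, within a range from 0.5 nM to 25 nM. This estimate means a step of a 3.0-fold higher number from compound 2 to compound 3 (0.48 log units; beyond the scatter), expected to be small and of uncertain direction.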

Compound 3, half-maximal effective concentration: 4 nM
Compound 3: middle estimate off by 1.3-fold (0.12 log units), on the low side; low and high end bracket the measured number.
By their numbers in this assay, from the lowest: compound 2; then compound 3; then compound 1.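

In this assay, the 4-fluorophenyl ring stays in place in both compound 2 and compound 3, yet replacing 4-fluorobenzyl with (4-fluorophenyl)carbonyl on an oxygen on a saturated carbon still moves the number beyond the scatter (a 4.0-fold higher number from compound 2 to compound 3 (0.60 log units; beyond the scatter)), so this position responds to a change in how the ring is attached and not only to a change of ring. The carbonyl-linked group also keeps its advantage over the group of compound 1, which carries a five-membered aromatic ring with two hetero atoms (a 2.5-fold lower number from compound 1 to compound 3 (0.40 log units; beyond the scatter)), and the three groups now fall into an order in which each gap lies beyond the scatter. Nothing measured here explains either step.

The compounds shown leave open how much of this order depends on the fluorine, which a plain phenyl ring or a chlorine-bearing ring would test. They also leave open how the number would respond to an amine or a carboxylic acid on the group at this oxygen, or to a longer chain between the oxygen and the ring.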